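A Single Stereocentre Changed at a Saturated Ring Carbon

A few compounds are considered here, and "the series" means these few. Any claim that something is new, unique, unknown or untested is made for them only; others in the source may bear on it.

Compound 1 (`Cc1cn([C@H]2C[C@H](CC3=CC(=O)C(=O)C=C3)[C@@H](CO[Si](C)(C)C(C)(C)C)O2)c(=O)[nH]c1=O`): no result reported
Compound 2 (`COc1ccc(C2([C@H]3C[C@H](n4cc(C)c(=O)[nH]c4=O)O[C@@H]3CO[Si](C)(C)C(C)(C)C)SCCCS2)cc1OC`): 2190 nM

In a functional assay on SF-539 cells (Homo sapiens) for inhibition, read by sulforhodamine B assay, with a stated time of 48 h (a lower number here means a stronger inhibitor of growth, a higher number a weaker inhibitor of growth), compound 2 gives 2190 nM and stands alone. Compound 1 has no reported result, so compound 2 cannot be ranked as strong or weak within this small set. It serves only as a single point of reference.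

The next compound to be tested is compound 3 (`COc1ccc(C2([C@H]3C[C@@H](n4cc(C)c(=O)[nH]c4=O)O[C@@H]3CO[Si](C)(C)C(C)(C)C)SCCCS2)cc1OC`). Its relation to compound 2 is unusually simple (the two compounds have the same atoms and bonds and differ only in configuration as drawn: 1 of 3 stereo elements differ; a stereocentre at a saturated ring carbon is drawn R in compound 2 and S in compound 3). The same atoms are joined by the same bonds, and a stereocentre at a saturated ring carbon is drawn R in compound 2 and S in compound 3. Such a pair asks whether configuration alone moves the number.

Among the compounds with values here, no measured pair here shows what a change of this kind does, so the data give no direction. In this assay the expectation is therefore no step beyond the scatter, although a larger move either way remains possible. Within the data shown here, the anchor is compound 2 at 2190 nM as the only measured value. The expected size of the change is a 1.1-fold higher number from compound 2 to compound 3 (0.06 log units; within the scatter) as estimated here. For compound 3 the estimate is 2500 nM with an expected range from 900 nM to 8000 nM in this test.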

Compound 3, concentration for 50% growth inhibition: 14100 nM
Compound 3: the middle estimate sits 5.6-fold (0.75 log units) below what was measured, outside the stated range (above it).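

In this assay, turning the stereocentre at a saturated ring carbon from R to S gives a 6.4-fold higher number from compound 2 to compound 3 (0.81 log units; beyond the scatter), so the S form drawn here is the weaker inhibitor of growth. Until now there was a single number with nothing to set it against, whereas this pair shows that, at least in this one comparison, configuration at this carbon moves the result beyond the usual scatter with no change in the groups present. The step can be assigned to this one stereocentre rather than to any added or lost group because of a single structural fact: the fact that compounds 2 and 3 differ only in the configuration as drawn

The other two stereo elements are the same in both compounds, so what they contribute remains open, and the pair does not show why the S form is weaker. It is also unknown whether the same preference for R would hold in a compound carrying a hydroxyl group or an amine on the shared core.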